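A few compounds are considered here, and "the series" means these few. Any claim that something is new, unique, unknown or untested is made for them only; others in the source may bear on it.

Compound 1 `C=C1C(=O)O[C@H]2CC3=C[C@H](C/C(C)=C/[C@@H](OC(=O)c4ccc(C(F)(F)F)cc4)[C@H]12)OC3=O` carries a 4-(trifluoromethyl)phenyl ester on the shared core. In a functional assay on A549 cells (Homo sapiens) for cytotoxicity, read by MTT assay, with a stated time of 48 h (on this read-out higher numbers stand for weaker inhibition and lower numbers for stronger inhibition), compound 1 gives only a limit, > 10000 nM, and not a number. Compound 2 `C=C1C(=O)O[C@H]2CC3=C[C@H](C/C(C)=C/[C@@H](OC(=O)/C=C/c4cccc(OC)c4)[C@H]12)OC3=O` bears 2-(3-methoxyphenyl)ethenyl on the same carbonyl carbon, and in this assay compound 2 gives 6200 nM. Compound 3 `C=C1C(=O)O[C@H]2CC3=C[C@H](C/C(C)=C/[C@@H](OC(=O)CCl)[C@H]12)OC3=O` carries chloromethyl there; in this assay compound 3 gives only a limit, > 10000 nM. The steps among these three are small or unreadable: an at least 1.6-fold lower number from compound 1 to compound 2 (0.20 log units; that floor lies within the scatter), a step that the two limits leave unreadable from compound 1 to compound 3 and an at least 1.6-fold higher number from compound 2 to compound 3 (0.20 log units; that floor lies within the scatter). Compound 1 thus sits at the limit, as does compound 3 (the limit of > 10000 nM in this assay, at which 2 of the 3 values shown sit). Compound 4 `C=C1C(=O)O[C@H]2CC3=C[C@H](C/C(C)=C/[C@@H](OC(=O)C4CCC(F)(F)CC4)[C@H]12)OC3=O` differs from compound 1 by one change: 4,4-difluorocyclohexyl in place of 4-(trifluoromethyl)phenyl on a carbonyl carbon. No measured step exchanges a six-membered aromatic ring for a six-membered non-aromatic ring on that carbonyl carbon, so the steps shown say only that the ester group has moved the read-out little, if at all. Compound 4 is therefore expected to stay near the limit, with a step that the limit leaves unreadable from compound 1 to compound 4 as the expected step. The estimate for compound 4 in this assay is 15000 nM, within 5000 nM to 40000 nM.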

Compound 4, half-maximal inhibitory concentration: 6400 nM
Beside the measured number, compound 4's estimate is 2.3-fold (0.37 log units) above it; the range from low to high includes it.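

Going by these compounds alone, with 4,4-difluorocyclohexyl on this carbonyl carbon, this assay gives a measured number for a non-aromatic ring for the first time, so a number here is not confined to the 2-(3-methoxyphenyl)ethenyl ester. The steps are an at least 1.5-fold lower number from compound 1 to compound 4 (0.19 log units; that floor lies within the scatter), an at least 1.5-fold lower number from compound 3 to compound 4 (0.19 log units; that floor lies within the scatter) and a 1.0-fold higher number from compound 2 to compound 4 (0.01 log units; within the scatter), so none of them is shown to lie beyond the scatter. Compound 1 and compound 3 still stand only as limits, not numbers: the limit of > 10000 nM in this assay, at which 2 of the 4 values shown sit.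

The compounds shown leave open whether any group on this carbonyl carbon can move the read-out beyond the scatter. They also leave open what an amine, a carboxylic acid or a longer carbon chain in this ester would give.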